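The source may report more compounds than this note shows. Statements on the series, on what has been measured and on what is new or still open speak of the compounds shown alone.

Of the compounds shown here, three have so far been tested in a functional assay on NSCLC cells (Homo sapiens) for cytotoxicity, read by sulforhodamine B assay, with a stated time of 48 h; a lower number here means a stronger inhibitor of growth, a higher number a weaker inhibitor of growth. Compound 1 (`COc1ccc2c(c1)/C(=C/c1c(-c3ccncc3)nc3sccn13)C(=O)N2C`) gives 550 nM, compound 2 (`COc1cc2c(cc1C)NC(=O)/C2=C/c1c(OC)nc2sc(C)cn12`) gives 5250 nM and compound 3 (`O=C1Nc2ccccc2C1=Cc1c(-c2ccncc2)nc2sccn12`) gives 8970 nM in this test. Compound 2 therefore lies within the scatter of compound 3 and well above compound 1, a gap that is beyond the scatter.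

Compound 4 (`COc1ccc2c(c1)/C(=C\c1c(OC)nc3sc(C)cn13)C(=O)N2`) has not yet been measured. It carries hydrogen in place of methyl on an aromatic carbon compared with compound 2 (hydrogen in place of methyl on an aromatic carbon). Within the data shown here, no measured pair differs in one place only, so the data offer no direct guide to this change. Compound 1 at 550 nM and compound 3 at 8970 nM both lack this methyl, yet they differ in other places and lie far apart, so they only loosely bracket the expectation. In this assay no step beyond the scatter is expected, only a slight move toward a lower number. An estimated 1.8-fold lower number from compound 2 to compound 4 (0.24 log units; within the scatter) is expected here. For compound 4 the estimated value is 3000 nM with an expected range of 900 nM to 9000 nM at this stage.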

Compound 4, concentration for 50% growth inhibition: 1490 nM
Beside the measured number, compound 4's estimate is 2.0-fold (0.30 log units) above it; the range from low to high includes it.
By their numbers in this assay, from the lowest: compound 1; then compound 4; then compounds 2 and 3 (each within the scatter of the next).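

In this assay, hydrogen in place of methyl on this aromatic carbon, ortho to a methoxy group, gives a 3.5-fold lower number from compound 2 to compound 4 (0.55 log units; beyond the scatter). Among these compounds, this is the first change that can be read in one place alone, and it shows that the methyl is not needed for growth inhibition here and that this position affects the result, since the step lies beyond the scatter. The data give no reason for this step.

The finding rests on a single pair, so the compounds shown leave open whether a fluorine or chlorine atom, an ethyl group or a hydroxyl group on this carbon would lower or raise the number. They also leave open whether the same change would have a similar effect on the core of compound 1.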